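The source may report more compounds than this note shows. Statements on the series, on what has been measured and on what is new or still open speak of the compounds shown alone.

Measured compounds:
compound 1 `C/C(=N\NC(=O)c1cccc(S(=O)(=O)N2CCOCC2)c1)c1cccc(N)c1`: > 100000 nM
compound 2 `C/C(=N\NC(=O)c1cccc(S(=O)(=O)N2CCOCC2)c1)c1cccc(O)c1`: > 100000 nM
compound 3 `C/C(=N\NC(=O)c1cccc(S(=O)(=O)N2CCOCC2)c1)c1cc(O)ccc1O`: 9090 nM

In a functional assay on MGC-803 cells (Homo sapiens) for antiproliferative activity, read by MTT assay, with a stated time of 72 h (a lower number here means a stronger inhibitor, a higher number a weaker inhibitor), compound 1 gives > 100000 nM, which is a limit of the assay rather than a number. Compound 2 likewise gives only the limit > 100000 nM. For the measured compounds named here, compound 3 gives 9090 nM, the only number among the three, so the steps of an at least 11-fold lower number from compound 1 to compound 3 (1.04 log units; beyond the scatter) and an at least 11-fold lower number from compound 2 to compound 3 (1.04 log units; beyond the scatter) are both read from the limit (the limit of > 100000 nM in this assay, at which 2 of the 3 values shown sit). The swap of amino for hydroxy, a step that the two limits leave unreadable from compound 1 to compound 2, cannot be sized.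

Compound 4 `C/C(=N\NC(=O)c1cccc(S(=O)(=O)N2CCOCC2)c1)c1cccc(N)c1O` differs from compound 3 by 3-amino-2-hydroxyphenyl in place of 2,5-dihydroxyphenyl on a carbon with a double bond to nitrogen. It keeps one hydroxy but trades the other for an amino, a change the measured steps only partly cover. A somewhat weaker result is expected, with an estimated step of a 2.2-fold higher number from compound 3 to compound 4 (0.34 log units; beyond the scatter). This gives for compound 4 an estimated 20000 nM, with an expected range from 5000 nM to 100000 nM.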

Compound 4, half-maximal inhibitory concentration: 530 nM
For compound 4 the middle estimate is 38-fold (1.58 log units) above the measured one, and the stated range ends above it.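

In this assay, swapping one ring substituent matters greatly: 3-amino-2-hydroxyphenyl in place of 2,5-dihydroxyphenyl gives a 17-fold lower number from compound 3 to compound 4 (1.23 log units; beyond the scatter), so on this carbon an amino group with one hydroxy outperforms two hydroxy groups. Two further steps, an at least 180-fold lower number from compound 1 to compound 4 (2.27 log units; beyond the scatter) and an at least 180-fold lower number from compound 2 to compound 4 (2.27 log units; beyond the scatter), each start from a limit of the assay rather than a number. Adding a hydroxy lowers the number on both aminophenyl and hydroxyphenyl starting points, but the sizes cannot be compared: the same change on two cores in this assay, an at least 11-fold lower number (1.04 log units; beyond the scatter) from compound 2 to compound 3 and an at least 180-fold lower number (2.27 log units; beyond the scatter) from compound 1 to compound 4; the limit leaves it open whether they differ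

On these data alone, whether a methoxy could replace the hydroxy of compound 4, or a dimethylamino group its amino, remains open.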